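Hydroxy to fluoro on two inactive cores

This account rests on a few compounds, and the source may have more. Where it says the series, first, only, none or still open, it means among the compounds named here.

Compounds 1 and 2 share one core and compounds 3 and 4 another; the difference between the two cores is not broken down here. Compound 1 `COc1nc(CC(O)(COC(C)=O)COC(C)=O)c(C)c(OC)n1` and compound 2 `COc1nc(CC(F)(COC(C)=O)COC(C)=O)c(C)c(OC)n1` were tested in a functional assay on HepG2 cells (Homo sapiens) for antiproliferative activity, read by MTT assay, with a stated time of 72 h; a higher number here means a weaker inhibitor, a lower number a stronger inhibitor. In this assay compound 1 gives > 100000 nM, which is a limit of the assay rather than a number. In this assay compound 2 gives > 100000 nM, again a limit. The change between them is fluoro in place of hydroxy on a saturated chain carbon bound to three saturated chain carbons, and the size of a step that the two limits leave unreadable from compound 1 to compound 2 cannot be read because of the limit of > 100000 nM in this assay, at which 3 of the 3 values shown sit.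

Compound 3 `CC(=O)OCC(O)(COC(C)=O)Cc1c(C)c(=O)[nH]c(=O)n1C` carries the hydroxy on the second core. In this assay compound 3 gives > 100000 nM, also a limit. Compound 4 `CC(=O)OCC(F)(COC(C)=O)Cc1c(C)c(=O)[nH]c(=O)n1C` has not yet been measured in this assay. The change is the same as before: fluoro in place of hydroxy on a saturated chain carbon bound to three saturated chain carbons.

The step is expected to be a step that the limit leaves unreadable from compound 3 to compound 4, resting on a step that the two limits leave unreadable from compound 1 to compound 2 and on (the limit of > 100000 nM in this assay, at which 3 of the 3 values shown sit). For compound 4 the expected value in this assay is 150000 nM, most likely again reported only as a limit.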

Compound 4, half-maximal inhibitory concentration: > 100000 nM
Compound 4: no number, only a limit; the forecaster's own chance of this, stated with the estimate: 85%; the middle value is on the limit's open side.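

For the compounds shown here, the step from compound 3 to compound 4 cannot be read, and neither can the one from compound 1 to compound 2, because all four compounds sit at the same limit, not at a number: the limit of > 100000 nM in this assay, at which 4 of the 4 values shown sit.

The compounds shown leave open whether fluoro in place of hydroxy changes activity at all on either core in this assay.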